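Removing the chloro from a trimethoxy chalcone

This account rests on a few compounds, and the source may have more. Where it says the series, first, only, none or still open, it means among the compounds named here.

Compound 1, `COc1cc(OC)c(C(=O)/C=C/c2ccc(Cl)cc2)c(OC)c1`, is the stronger of the two measured compounds in a functional assay on PC-3 cells (Homo sapiens), read by fluorescence and BrdU incorporation, with a stated time of 48 h, tested at 10 uM; a higher number here means a weaker effect of the compound at the concentration tested, a lower number a stronger effect: compound 1 gives 15%. The other measured compound, compound 2, `COc1cc(O)c(C(=O)/C=C/c2ccccc2SC)c(OC)c1`, gives 35% in this assay, a number higher than that of compound 1 by a gap that lies beyond the scatter. These two differ in more than one place, so their two values alone are all that can be said of them.

Compound 3, `COc1cc(OC)c(C(=O)/C=C/c2ccccc2)c(OC)c1`, is the compound still to be measured. It differs from compound 1 in one place: hydrogen in place of chloro on an aromatic carbon. Going by the values given here, with no measured pair carrying this same change, the size of the step must be guessed. For this assay the step from compound 1 to compound 3 is expected to be small and upward, possibly within the scatter, an expected a number 10 percentage points higher from compound 1 to compound 3 (within the scatter). Compound 3 is therefore estimated to give 25% in this assay, within a range from 8% to 45%.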

Compound 3, a percentage reported as activity, at one concentration (the size of the read-out at that concentration, not a potency): 24%
Beside the measured number, compound 3's estimate is 1 percentage points above it; the range from low to high includes it.
By their numbers in this assay, from the lowest: compounds 1 and 3 (each within the scatter of the next); then compound 2.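

Going by these compounds alone, replacing chloro with hydrogen on an aromatic carbon gives, in this assay, a number 9 percentage points higher from compound 1 to compound 3 (within the scatter), the first step in this set that can be read at a single place. The two compounds are not separated by this assay, so the chloro of the 4-chlorophenyl group is not required for the effect seen at the concentration tested: compound 3, with phenyl in its place, gives a reading within the scatter of that of compound 1. Nothing available explains this outcome.

From the compounds shown here alone, whether an amine or a carboxylic acid on the same aromatic carbon would also stay within the scatter remains open. Within the data shown here, compound 2 differs from both compound 1 and compound 3 in more than one place, so no step to it can be read.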